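The source may report more compounds than this note shows. Statements on the series, on what has been measured and on what is new or still open speak of the compounds shown alone.

Working notes on the series. Compound 1 `Nc1nc(SCc2ccccc2)nc2c1nc(O)n2Cc1ccccc1` gives 0.1 uM in a functional assay (spleen, spleen) for activation, with Mus musculus as the target; on this read-out higher numbers stand for an effect only at larger amounts of compound and lower numbers for an effect already at smaller amounts. Going by the values given here, compound 2 `CCCCNc1nc(N)c2nc(O)n(Cc3ccccc3)c2n1` gives 1 uM in this assay, the higher of the two numbers measured so far, with a 10-fold higher number from compound 1 to compound 2 (1.00 log units; beyond the scatter). Compound 3 `CCOc1nc(N)c2nc(O)n(Cc3ccccc3)c2n1` differs from compound 2 in one place: ethoxy in place of butylamino on an aromatic carbon. Among the compounds with values here, the one measured step, from compound 1 to compound 2, put butylamino in place of benzylsulfanyl on an aromatic carbon and was modest; it bears on the new change only loosely, and no measured step exchanges butylamino for an oxygen-linked chain. Both groups in the new step carry no ring, so a step within the scatter is expected, no change at the digits printed from compound 2 to compound 3 (within the scatter). Compound 3 is expected to give 1 uM in this assay, with a range of 0.3 uM to 3 uM.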

Compound 3, minimum effective concentration: 0.1 uM
Compound 3: the middle estimate sits 10-fold (1.00 log units) above what was measured; the whole stated range lies above it.
By their numbers in this assay, from the lowest: compounds 1 and 3 (each within the scatter of the next); then compound 2.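

In this assay the position between two ring nitrogen atoms responds to the group it carries: ethoxy in place of butylamino gives a 10-fold lower number from compound 2 to compound 3 (1.00 log units; beyond the scatter). Ethoxy in place of benzylsulfanyl gives no change at the digits printed from compound 1 to compound 3 (within the scatter), so a group with no ring can match one with a ring at this position. No available data account for either step.

Ethoxy differs from butylamino in both its linking atom and its chain, so the compounds shown do not separate the two changes. Butoxy or ethylamino at this position would separate them.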